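This account rests on a few compounds, and the source may have more. Where it says the series, first, only, none or still open, it means among the compounds named here.

Measured compounds:
- Compound 1 `COc1cc(CN(C(=O)Nc2ccc(C#N)cc2)n2cnnc2)cc(OC)c1OC`: > 50000 nM in a functional assay on MDA-MB-231 cells (Homo sapiens) for cytotoxicity, read by MTT assay, with a stated time of 48 h; on this read-out lower numbers stand for stronger inhibition and higher numbers for weaker inhibition
- Compound 2 `O=C(NCc1ccccc1)N(Cc1ccccn1)n1cnnc1`: > 50000 nM in this assay
- Compound 3 `Cc1ccsc1CN(C(=O)Nc1ccc(Cl)c(C(F)(F)F)c1)n1cnnc1`: 29600 nM in this assay

Compound 2 stands at a limit in this assay: its value is a cut-off of the assay, not a measured number, and it is one of two such limits in the set (the limit of > 50000 nM in this assay, at which 2 of the 3 values shown sit). Compound 1 sits at the same limit. Only compound 3, with its value of 29600 nM, gives a number at all, and that number is weak.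

The next compound, compound 4 `Cc1ccc(NC(=O)N(Cc2ccccn2)n2cnnc2)cc1`, is built from compound 2 by moving the same atoms into a new arrangement: 4-methylphenyl in place of benzyl on an amide-type nitrogen. With this change compound 4 joins compound 1 and compound 3 in carrying an aryl group on the urea nitrogen, whereas compound 2 carried a benzyl there.

For the measured compounds named here, no measured step connects compound 2 to compound 4, and nothing in the set points to a large gain. Of the two aryl ureas already measured, one sits at the limit and the other gives only a weak number. The step from compound 2 to compound 4 is therefore expected to be small, an at least 1.1-fold lower number from compound 2 to compound 4 (0.04 log units; that floor lies within the scatter), and most likely to stay within the scatter or to end at the limit again.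

Compound 4 is expected to give about 45000 nM in this assay, within the range 20000 nM to 100000 nM.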

Compound 4, half-maximal inhibitory concentration: 39500 nM
Beside the measured number, compound 4's estimate is 1.1-fold (0.06 log units) above it; low and high end bracket the measured number.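

For the compounds shown here, compound 4 gives a measured number where compound 2 gives only a limit, which makes 4-methylphenyl in place of benzyl on this amide-type nitrogen the first change in one place that can be read at all in this assay. The reading is one-sided: the change gives an at least 1.2-fold lower number from compound 2 to compound 4 (0.10 log units; that floor lies within the scatter), so it shows a direction that cannot be separated from ordinary repeat variation, and the number for compound 4 remains weak. Compound 2 stands at a limit of the assay, so the full size of the step cannot be told, and the result fixes only its lower bound: the limit of > 50000 nM in this assay, at which 2 of the 4 values shown sit.

The compounds shown leave open whether the methyl of the 4-methylphenyl group counts for anything, since a single step cannot separate it from the loss of the benzyl carbon chain, and whether plain phenyl would read the same. They also leave open whether a carboxylic acid or an amine on that aromatic ring, or a longer chain such as 2-phenylethyl on this nitrogen, would move the value clearly beyond the scatter.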